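The source may hold more compounds than are shown below. What is called first, only, known or untested is meant among the compounds shown, and "the series" means these compounds.

Measured so far in a functional assay on QGY-7703 cells (Homo sapiens) for cytotoxicity, read by MTT assay, with a stated time of 24 h (a lower number here means a stronger inhibitor, a higher number a weaker inhibitor), for three compounds
- Compound 1 `O=C1/C(=C/c2ccncc2)CN(S(=O)(=O)c2ccc(C(F)(F)F)cc2)C/C1=C\c1ccccc1F` gives 9500 nM
- Compound 2 `O=C1/C(=C/c2ccncc2)CN(S(=O)(=O)c2ccc(F)cc2)C/C1=C\c1ccccc1F` gives 9100 nM
- Compound 3 `O=C1/C(=C/c2ccncc2)CN(S(=O)(=O)c2ccc(Br)cc2)C/C1=C\c1ccccc1F` gives 11500 nM

Compound 1 stands level with the other two. Its nearest neighbour is given by a 1.0-fold lower number from compound 1 to compound 2 (0.02 log units; within the scatter) and its furthest by a 1.2-fold higher number from compound 1 to compound 3 (0.08 log units; within the scatter) so these numbers show no real order.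

Compound 4 `O=C1/C(=C/c2ccncc2)CN(S(=O)(=O)c2ccc(C(F)(F)F)cc2)C/C1=C\c1ccccc1C(F)(F)F` is still unmeasured. Among the measured compounds shown here, its single change from compound 1 is trifluoromethyl in place of fluoro on an aromatic carbon and this turns 2-fluorophenyl into 2-(trifluoromethyl)phenyl, on an aromatic carbon, ortho to a large group. The closest evidence is an exchange of the same two groups elsewhere in the molecule, seen in a 1.0-fold lower number from compound 1 to compound 2 (0.02 log units; within the scatter) and read in reverse. The swap in a 1.3-fold higher number from compound 2 to compound 3 (0.10 log units; within the scatter) was similarly small. For the measured compounds named here, no measured compound alters the 2-fluorophenyl group itself, so this support is indirect and the range must stay wide. No step beyond the scatter is expected in this assay and the estimated step is no change at the digits printed from compound 1 to compound 4 (within the scatter) in size. Compound 4 is estimated at 9500 nM with an expected range of 4500 nM to 20000 nM for its measurement.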

Compound 4, half-maximal inhibitory concentration: 4680 nM
Beside the measured number, compound 4's estimate is 2.0-fold (0.31 log units) above it; low and high end bracket the measured number.
By their numbers in this assay, from the lowest: compounds 4, 2, 1 and 3 (each within the scatter of the next, the first and the last beyond it).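

In this assay, among the compounds shown here, the change from 2-fluorophenyl to 2-(trifluoromethyl)phenyl gives a 2.0-fold lower number from compound 1 to compound 4 (0.31 log units; beyond the scatter) and is the only step so far to pass the scatter, though it is modest. For the compounds shown here, the earlier exchanges among fluoro, trifluoromethyl and bromo, made elsewhere in the molecule, all stayed within the scatter, so this is the first sign that the number can respond to a change at this position, and that the same exchange of groups need not count equally at both places. Nothing available explains this shift.

Going by these compounds, with one change at this position, it remains open whether the trend would extend to chloro, methyl or methoxy here. An amine or a carboxylic acid in this place is also untested among the compounds shown, as is the same trifluoromethyl swap on the core of compound 2 or compound 3.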